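Methyl in Place of Sulfamoyl: an Estimate for Compound 3

The source may hold more compounds than are shown below. What is called first, only, known or untested is meant among the compounds shown, and "the series" means these compounds.

Measured in a functional assay (Pituitary gland cell) with Rattus norvegicus as the target; on this read-out lower numbers stand for an effect already at smaller amounts and higher numbers for an effect only at larger amounts of compound:
compound 1 `COC(=O)c1ccccc1-c1ccc(CN2C(=O)[C@H](NC(=O)CC(C)(C)N)CCc3ccccc32)cc1` gives 2 uM
compound 2 `CC(C)(N)CC(=O)N[C@@H]1CCc2ccccc2N(Cc2ccc(-c3ccccc3S(N)(=O)=O)cc2)C1=O` gives 3 uM

Compound 2 stands at the larger of the two numbers, yet a 1.5-fold higher number from compound 1 to compound 2 (0.18 log units; within the scatter) is within the scatter, so the two cannot be told apart. Compound 3 `Cc1ccccc1-c1ccc(CN2C(=O)[C@H](NC(=O)CC(C)(C)N)CCc3ccccc32)cc1` is not yet measured; it differs from compound 2 by methyl in place of sulfamoyl on an aromatic carbon. Among the measured compounds shown here, only one measured step bears on this, and it says that exchanging one group on that aromatic carbon for another left the number within the scatter. No step beyond the scatter is therefore expected in this assay, that is no change at the digits printed from compound 2 to compound 3 (within the scatter). Compound 3 is estimated at 3 uM, between 1 uM and 10 uM.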

Compound 3, concentration for half-maximal effect: 1 uM
For compound 3 the middle estimate is 3.0-fold (0.48 log units) above the measured one, and the stated range covers the measured number.
By their numbers in this assay, from the lowest: compounds 3, 1 and 2 (each within the scatter of the next, the first and the last beyond it).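

At this aromatic carbon, a change of group now moves the number beyond the scatter in this assay, with methyl replacing sulfamoyl giving a modest step (a 3.0-fold lower number from compound 2 to compound 3 (0.48 log units; beyond the scatter)). Methyl replacing methoxycarbonyl, by contrast, stays within the scatter (a 2.0-fold lower number from compound 1 to compound 3 (0.30 log units; within the scatter)), so only the exchange of sulfamoyl for methyl can be read as a change. Nothing available explains this step. Still open, from the compounds shown here alone, is how an amine, a carboxylic acid or a longer chain such as ethyl would read at this aromatic carbon.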